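The source may hold more compounds than are shown below. What is called first, only, known or untested is meant among the compounds shown, and "the series" means these compounds.

Of the compounds shown here, three sharing one core have been measured in an assay on isolated protein for inhibition of Dihydrofolate reductase (Mus musculus); a higher number here means a more potent compound, by a factor of ten per unit of this negative logarithm, a lower number a less potent compound. Compound 1 `CC1(C)N=C(N)N=C(N)N1c1ccc(OCc2cccc(S(=O)(=O)F)c2)c(Cl)c1` gives 7.72. Compound 2 `CC1(C)N=C(N)N=C(N)N1c1ccc(OCc2ccc(S(=O)(=O)F)cc2)c(Cl)c1` gives 7.58 in this assay; it has the same atoms as compound 1 joined differently, and the difference between the two cores is not broken down here. Compound 3 `CC1(C)N=C(N)N=C(N)N1c1ccc(OCc2cccc(S(=O)(=O)F)c2Cl)c(Cl)c1` gives 7.49 in this assay. Compound 3 arises from compound 1 by chloro in place of hydrogen on an aromatic carbon, and that change made a step of a number 0.23 log units lower from compound 1 to compound 3 (within the scatter).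

Compound 4 `CC1(C)N=C(N)N=C(N)N1c1ccc(OCc2ccc(S(=O)(=O)F)cc2Cl)c(Cl)c1` has not yet been measured. It arises from compound 2 by chloro in place of hydrogen on an aromatic carbon. Among the measured compounds shown here, this is the same kind of change as the one from compound 1 to compound 3, but not the same: in compound 3 the entering chloro sits ortho to a fluorosulfonyl group and ortho to a large group, whereas in compound 4 it sits ortho to a large group and meta to a fluorosulfonyl group. Because the earlier change gave only a number 0.23 log units lower from compound 1 to compound 3 (within the scatter), a step of similar size is expected here, estimated as a number 0.18 log units lower from compound 2 to compound 4 (within the scatter). Compound 4 is therefore estimated at 7.4 in this assay, likely between 7 and 7.8.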

Compound 4, logarithm of the reciprocal of the active concentration, log(1/C): 7.44
For compound 4 the middle estimate is 0.04 log units below the measured one; low and high end bracket the measured number.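

In this assay, chloro in place of hydrogen on an aromatic carbon gives a number 0.14 log units lower from compound 2 to compound 4 (within the scatter), and setting this beside the earlier case shows that the change reads alike on both cores: the same change on two cores in this assay, a number 0.23 log units lower (within the scatter) from compound 1 to compound 3 and a number 0.14 log units lower (within the scatter) from compound 2 to compound 4, 0.09 log units apart, within the scatter of two such steps. Within these two pairs, then, the change carries over from one core to the other, and neither step can be told apart from the ordinary variation between repeated measurements. This does not show that chloro would behave the same way on other cores or at other places on the ring, nor can steps this small reveal a slight real difference between the two cores.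

The compounds shown leave open what a different group, such as methoxy or an amine, would do on this same aromatic carbon, where only hydrogen and chloro appear here. They also leave open how the numbers would move with a carboxylic acid in place of the fluorosulfonyl group.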